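Working notes: the carbonyl substituent in a small series

The compounds below may be only part of what the source reports. "The series", "measured", "known", "first", "only" and "open" are said of these compounds alone.

Measured in a functional assay on MCF7 cells (Homo sapiens) for inhibition, read by radiometric assay and XTT assay (a higher number here means a weaker inhibitor, a lower number a stronger inhibitor), as follows
compound 1 `CCCCCCCC[C@@]1(C)SC(O)=C(C(C)O)C1=O` gives 23.9 ug/mL; 21 ug/mL (2 entries)
compound 2 `CCCCCCCC[C@@]1(C)SC(O)=C(C(C)=O)C1=O` gives 12.5 ug/mL
compound 3 `CCCCCCCC[C@@]1(C)SC(O)=C(C(=O)C(F)(F)F)C1=O` gives 18.4 ug/mL

Compound 3 is not separated from compound 2 beyond the scatter. Among the measured compounds shown here, the one measured step on a carbonyl carbon is a 1.5-fold higher number from compound 2 to compound 3 (0.17 log units; within the scatter) and it puts trifluoromethyl in place of methyl. The repeat entries for compound 1 agree closely (the several entries of compound 1 in this assay, 23.9 ug/mL; 21 ug/mL (2 entries)) and give a sense of reproducibility in this assay for this series.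

Compound 4 `CCCCCCCC[C@@]1(C)SC(O)=C(C(=O)OC)C1=O` carries methoxy in place of trifluoromethyl on a carbonyl carbon and has not yet been measured. For the measured compounds named here, no measured step puts methoxy on this carbonyl carbon. The closest guide is the change from methyl to trifluoromethyl, and that change stayed within the scatter (a 1.5-fold higher number from compound 2 to compound 3 (0.17 log units; within the scatter)). No step beyond the scatter is therefore expected in this assay and no direction is assumed. The estimated step is a 1.0-fold lower number from compound 3 to compound 4 (0.01 log units; within the scatter) on this reasoning. For compound 4 the expected value is 18 ug/mL with an estimated range from 9 ug/mL to 36 ug/mL as its upper end.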

Compound 4, half-maximal inhibitory concentration: 47.2 ug/mL
For compound 4 the middle estimate is 2.6-fold (0.42 log units) below the measured one; the whole stated range lies below it.
By their numbers in this assay, from the lowest: compounds 2 and 3 (each within the scatter of the next); then compound 4.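

Up to this point the carbonyl substituent looked tolerant, since methyl and trifluoromethyl could not be told apart in this assay. Methoxy is the first group on this carbonyl carbon to move the number beyond the scatter, with a 2.6-fold higher number from compound 3 to compound 4 (0.41 log units; beyond the scatter) and a 3.8-fold higher number from compound 2 to compound 4 (0.58 log units; beyond the scatter), both modest steps towards a weaker inhibitor, so this position does respond to at least one change of group. These steps are also wider than the spread between repeat readings within the series, which supports treating them as real rather than as noise: the several entries of compound 1 in this assay, 23.9 ug/mL; 21 ug/mL (2 entries)

Among the compounds shown here, the series holds only three groups on this carbonyl carbon, so it remains open whether an amine or ethoxy there would read with methoxy or with methyl and trifluoromethyl. The compounds shown come with no measured property of these groups. The whole comparison rests on this one cell assay.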